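This account rests on a few compounds, and the source may have more. Where it says the series, first, only, none or still open, it means among the compounds named here.

Working notes on the series.

Two compounds of the shared core have numbers in an ADME assay on the whole organism with Oryza sativa as the target, tested at 0.1 uM; a lower number here means a stronger effect, a higher number a weaker effect of the compound at the concentration tested. Compound 1 `CC(C)c1cccc(NC(=O)N[C@H](C)c2ccccc2)c1` gives 74%. Compound 2 `CCOC(=O)c1cccc(NC(=O)N[C@H](C)c2ccccc2)c1` gives 99%, the highest of the two numbers, with compound 1 the nearest at a number beyond the scatter below it. Among the measured compounds shown here, the one step seen so far, ethoxycarbonyl in place of isopropyl on an aromatic carbon, runs a number 25 percentage points higher from compound 1 to compound 2 (beyond the scatter).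

Compound 3 `C[C@@H](NC(=O)Nc1cccc(Cl)c1)c1ccccc1` is not yet measured in this assay. It differs from compound 2 as follows: chloro in place of ethoxycarbonyl on an aromatic carbon. The change sits on the same aromatic carbon that was altered in the step from compound 1 to compound 2, and the group that leaves is the same ethoxycarbonyl that entered there. That step is the only one that bears on the present change, and it was modest in size. For the measured compounds named here, since the ethoxycarbonyl is removed again, a step back toward lower numbers of about that order is expected, though the chloro that enters has no precedent here. For compound 3 the estimate in this assay is 80%, within a range of 60% to 99%, which would mean an expected step of a number 19 percentage points lower from compound 2 to compound 3 (beyond the scatter).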

Compound 3, a percentage reported as activity, at one concentration (the size of the read-out at that concentration, not a potency): 97%
Estimate against measurement, compound 3: 17 percentage points below; low and high end bracket the measured number.
By their numbers in this assay, from the lowest: compound 1; then compounds 3 and 2 (each within the scatter of the next).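

At this aromatic carbon, taking out the ethoxycarbonyl does not by itself bring the number down in this assay: chloro in its place runs a number 2 percentage points lower from compound 2 to compound 3 (within the scatter), so a group of 5 heavy atoms with 2 hydrogen-bond acceptors and a single chlorine with none cannot be told apart here. Chloro in place of isopropyl runs a number 23 percentage points higher from compound 1 to compound 3 (beyond the scatter), which, together with a number 25 percentage points higher from compound 1 to compound 2 (beyond the scatter), makes two different replacements of isopropyl that each end beyond the scatter, so among the three compounds only compound 1 stands apart. Nothing at hand explains why these three groups read as they do.

The compounds shown leave open whether the lower number belongs to isopropyl alone or would also appear with an ethyl or a tert-butyl on the same aromatic carbon, and how an amine or a carboxylic acid would read there. They also leave open whether the same ranking of groups would hold with any change to the shared core away from this carbon.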